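Swapping the aniline ring on a quinoxaline-type sulfone core

A few compounds are considered here, and "the series" means these few. Any claim that something is new, unique, unknown or untested is made for them only; others in the source may bear on it.

Of the compounds shown here, two of a shared core have been tested in a functional assay on HCT-116 cells (Homo sapiens) for cytotoxicity, read by MTT assay, with a stated time of 72 h; on this read-out lower numbers stand for stronger inhibition and higher numbers for weaker inhibition. Compound 1 `COc1cc(Nc2nc3ccccc3nc2S(=O)(=O)c2ccccc2)cc(OC)c1` gives 950 nM. Compound 2 `COc1ccc(Nc2nc3ccccc3nc2S(=O)(=O)c2ccc(OC)cc2)cc1` gives 29100 nM, the higher of the two numbers and the weaker inhibition, a gap beyond the scatter of repeated measurements. The two differ in more than one place, so no single change can be credited for that gap.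

Compound 3 `COc1ccc(S(=O)(=O)c2nc3ccccc3nc2Nc2cc(OC)cc(OC)c2)cc1` is the next compound to be measured in this assay. It differs from compound 2 in one place: 3,5-dimethoxyphenyl in place of 4-methoxyphenyl on a nitrogen on an aromatic ring. Compound 1, which carries the same 3,5-dimethoxyphenyl, gives 950 nM, but it differs from compound 3 elsewhere in the molecule as well, so the part played by this change alone is not known.

Given the stronger inhibition of compound 1, the step from compound 2 to compound 3 is expected to be downward and beyond the scatter, namely a 6.5-fold lower number from compound 2 to compound 3 (0.81 log units; beyond the scatter). Compound 3 is expected to give about 4500 nM, with a range of 1200 nM to 18000 nM.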

Compound 3, half-maximal inhibitory concentration: 13400 nM
Estimate against measurement, compound 3: 3.0-fold (0.47 log units) below; the measured number falls inside the stated range.
By their numbers in this assay, from the lowest: compound 1; then compound 3; then compound 2.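

In this assay, the change of 4-methoxyphenyl to 3,5-dimethoxyphenyl on the nitrogen can now be read by itself: it gives a 2.2-fold lower number from compound 2 to compound 3 (0.34 log units; beyond the scatter), a modest step towards stronger inhibition. Compound 3 also isolates a second change, methoxy in place of hydrogen on an aromatic carbon, which gives a 14-fold higher number from compound 1 to compound 3 (1.15 log units; beyond the scatter), a large step towards weaker inhibition. Of these two single changes, the methoxy on the aromatic carbon goes with the larger step and the opposite direction, and nothing given here explains either step.

Whether the two changes simply add up, or the effect of one depends on the other, stays open, as the compounds shown hold only one step of each kind. On these data alone, it is also open whether a group other than methoxy at that aromatic carbon, such as a fluorine atom, a hydroxy group or an amine, would give a step of similar size and the same direction.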